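The compounds below may be only part of what the source reports. "The series", "measured", "known", "first", "only" and "open" are said of these compounds alone.

Compound 1 `Cn1c(/C=C/C(=O)c2ccccc2O)cc(Br)c1Br` and compound 2 `Cn1c(/C=C/C(=O)c2ccc[nH]2)cc(Br)c1Br` share the doubly brominated five-membered ring with a methyl on its aromatic nitrogen; the difference between the two cores is not broken down here. In a functional assay on WRL68 cells (Homo sapiens) for cytotoxicity, read by MTT assay, with stated times of 6 h and 48 h (on this read-out higher numbers stand for weaker inhibition and lower numbers for stronger inhibition), compound 1 gives 330 nM, and compound 2 gives 2110 nM. Compound 3 `O=C(/C=C/c1cc(Br)c(Br)[nH]1)c1ccccc1O` carries hydrogen in place of methyl on an aromatic nitrogen and gives 1420 nM in this assay, so the step of a 4.3-fold higher number from compound 1 to compound 3 (0.63 log units; beyond the scatter) is seen. Compound 4 `O=C(/C=C/c1cc(Br)c(Br)[nH]1)c1ccc[nH]1` carries hydrogen in place of methyl on an aromatic nitrogen and awaits measurement in this assay. This is the same kind of change, though here the ring atom next to the nitrogen bears a group of 9 heavy atoms rather than a large group. Resting on the step from compound 1 to compound 3, a step of similar direction, a 2.8-fold higher number from compound 2 to compound 4 (0.45 log units; beyond the scatter), is expected for compound 4. Compound 4 is therefore estimated at 6000 nM, between 2500 nM and 15000 nM.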

Compound 4, half-maximal inhibitory concentration: >= 100000 nM
Compound 4: only a limit was reported (the forecaster's own chance of this, stated with the estimate: 20%); middle value at least 16-fold (1.22 log units) away from the limit.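

In this assay, hydrogen in place of methyl on the aromatic nitrogen gives an at least 47-fold higher number from compound 2 to compound 4 (1.67 log units; beyond the scatter) and so moves the number in the same direction as on the core of compound 1. The size of the change does not carry over from one core to the other: the same change on two cores in this assay, a 4.3-fold higher number (0.63 log units; beyond the scatter) from compound 1 to compound 3 and an at least 47-fold higher number (1.67 log units; beyond the scatter) from compound 2 to compound 4, at least 11-fold (1.04 log units) apart, beyond the scatter of two such steps. On these data alone, for compound 4 the value >= 100000 nM is a limit of the assay and not a number, so the true size of this step remains unknown, and the two pairs do not show what sets the two cores apart.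

The compounds shown leave open whether such a gap would recur on other cores. Also open, as far as these compounds go, is what an ethyl group or a longer chain on that nitrogen, or an amine in place of a bromo group, would give.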